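A Fluoro Step on the 2-Aminophenyl Group

The source may report more compounds than this note shows. Statements on the series, on what has been measured and on what is new or still open speak of the compounds shown alone.

Among the measured compounds shown here, in a functional assay on MGC-803 cells (Homo sapiens) for antiproliferative activity, read by CCK-8 assay, with a stated time of 72 h (on this read-out lower numbers stand for stronger inhibition and higher numbers for weaker inhibition), compound 3 `Nc1ccccc1NC(=O)c1ccc(COc2ccccc2)cc1` gives 5670 nM, the only actual number in this small set. Compound 1 `Nc1ccccc1NC(=O)c1ccc(COc2ccc([N+](=O)[O-])cc2)cc1` reads > 32000 nM, which is a limit of the assay and not a number. For compound 2 `O=C(NO)c1ccc(COc2ccccc2)cc1` the entry is "not determined" (no result reported).

Compound 4 `Nc1cc(F)ccc1NC(=O)c1ccc(COc2ccccc2)cc1` differs from compound 3 by fluoro in place of hydrogen on an aromatic carbon, which turns 2-aminophenyl to 2-amino-4-fluorophenyl: fluoro in place of hydrogen on an aromatic carbon. For the measured compounds named here, the only measured step is an at least 5.6-fold lower number from compound 1 to compound 3 (0.75 log units; beyond the scatter), with hydrogen in place of nitro on an aromatic carbon, and it rests on (the limit of > 32000 nM in this assay, at which 1 of the 3 values shown sits). That step leaves the 2-aminophenyl group untouched and offers no direct guide to a fluoro change, though it shows that a single substitution can register in this assay. Starting from compound 3 at 5670 nM, only a small shift toward a lower number is expected, not beyond the scatter. The expected step is a 1.4-fold lower number from compound 3 to compound 4 (0.15 log units; within the scatter). Compound 4 is estimated at 4000 nM, with an expected range from 1600 nM to 10000 nM.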

Compound 4, half-maximal inhibitory concentration: 6020 nM
The estimate for compound 4 lay 1.5-fold (0.18 log units) below the measured number; measured number inside the range.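

In this assay, among the compounds shown here, the series shows a 1.1-fold higher number from compound 3 to compound 4 (0.03 log units; within the scatter) and so gives the first reading on the 2-aminophenyl group itself, since the earlier step left that group untouched. At this aromatic carbon, meta to the amino group and para to a large group, fluoro in place of hydrogen leaves the antiproliferative read-out indistinguishable from that of the unsubstituted parent, and a single substitution here does not register as the nitro change did elsewhere. The values shown give no explanation for this reading.

From the compounds shown here alone, whether a chloro, methoxy or trifluoromethyl group at the same carbon would also leave the number unchanged remains open. So does whether fluoro on another carbon of this ring would read the same way.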